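This account rests on a few compounds, and the source may have more. Where it says the series, first, only, none or still open, it means among the compounds named here.

Measured so far:
- compound 1, `CCCCCCCCCCn1cc(/C=C/C(=O)c2ccc(NC(=O)CN3CCN(c4ccccc4)CC3)cc2)nn1`: 52100 nM
- compound 2, `O=C(CN1CCN(c2ccccc2)CC1)Nc1ccc(C(=O)/C=C/c2cn(Cc3ccc(Br)cc3)nn2)cc1`: 42100 nM
- compound 3, `CC(C)(C)OC(=O)N1CCN(CC(=O)Nc2ccc(C(=O)/C=C/c3cn(Cc4ccc(Br)cc4)nn3)cc2)CC1`: 38400 nM

All three were tested in a functional assay on A549 cells (Homo sapiens) for inhibition, read by MTT assay (a lower number here means a stronger inhibitor, a higher number a weaker inhibitor), and all three give numbers of the same general size, so none of them can be called more or less potent than another.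

Compound 2 and compound 1 share a core and differ in one place: nonyl in place of 4-bromophenyl on a saturated chain carbon bound to an aromatic nitrogen. This change gave a 1.2-fold higher number from compound 2 to compound 1 (0.09 log units; within the scatter), a step that lies within the usual scatter of repeated measurements.

Compound 3 shares its core with compound 4 but not with compound 2. The two cores differ in one place: tert-butoxycarbonyl in place of phenyl on an amine nitrogen in a ring. This change gave a 1.1-fold lower number from compound 2 to compound 3 (0.04 log units; within the scatter), again within the scatter.

Compound 4, `CCCCCCCCCCn1cc(/C=C/C(=O)c2ccc(NC(=O)CN3CCN(C(=O)OC(C)(C)C)CC3)cc2)nn1`, has not yet been measured. It is related to compound 3 by nonyl in place of 4-bromophenyl on a saturated chain carbon bound to an aromatic nitrogen. This is the same change that leads from compound 2 to compound 1, made at the same place and on a core that differs only by the group described above.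

Since that earlier change gave a 1.2-fold higher number from compound 2 to compound 1 (0.09 log units; within the scatter), a step of about the same size is expected here, a 1.2-fold higher number from compound 3 to compound 4 (0.08 log units; within the scatter), and the number expected for compound 4 in this assay is 46000 nM, with a likely range from 23000 nM to 92000 nM. This expectation rests on a single earlier step, so it is held loosely.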

Compound 4, half-maximal inhibitory concentration: 45400 nM
Compound 4: the middle estimate sits 1.0-fold (0.01 log units) above what was measured; the range from low to high includes it.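

In this assay, putting nonyl in place of 4-bromophenyl on the core carrying tert-butoxycarbonyl gave a 1.2-fold higher number from compound 3 to compound 4 (0.07 log units; within the scatter), and this step agrees with the one seen for the same change on the core carrying phenyl: the same change on two cores in this assay, a 1.2-fold higher number (0.09 log units; within the scatter) from compound 2 to compound 1 and a 1.2-fold higher number (0.07 log units; within the scatter) from compound 3 to compound 4, 1.0-fold (0.02 log units) apart, within the scatter of two such steps. The second change, tert-butoxycarbonyl in place of phenyl on an amine nitrogen in a ring, gave a 1.1-fold lower number from compound 1 to compound 4 (0.06 log units; within the scatter) on the core carrying nonyl, and it agrees in the same way with its earlier counterpart: the same change on two cores in this assay, a 1.1-fold lower number (0.04 log units; within the scatter) from compound 2 to compound 3 and a 1.1-fold lower number (0.06 log units; within the scatter) from compound 1 to compound 4, 1.0-fold (0.02 log units) apart, within the scatter of two such steps. Both changes therefore carried over from one core to the other in these four compounds, but every step lies within the scatter, so this is agreement among steps too small to tell apart from no change at all, and it does not show that either change truly alters the number or that a larger step would carry over as well.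

The compounds shown leave open whether any group at these two places can move the number beyond the scatter. A shorter chain or a chain ending in a carboxylic acid on the saturated chain carbon bound to an aromatic nitrogen, or an acetyl group or a plain hydrogen on the amine nitrogen in a ring, would put that question to the test.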